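Swapping phenyl for furan-3-yl in a growth inhibition test

The compounds below may be only part of what the source reports. "The series", "measured", "known", "first", "only" and "open" are said of these compounds alone.

Values so far in a functional assay on U-373MG ATCC cells for inhibition, with U373 MG (Homo sapiens) as the target, read by MTT assay, with a stated time of 7 days (a higher number here means a weaker inhibitor of growth, a lower number a stronger inhibitor of growth), are these:
- compound 1 `COc1ccc(Cn2nnc3c(C(N)=O)ncn3c2=O)c(OC)c1` gives > 50000 nM (a limit)
- compound 2 `NC(=O)c1ncn2c(=O)n(C(c3ccccc3)c3ccccc3)nnc12` gives > 50000 nM (a limit)
- compound 3 `NC(=O)c1nc[nH]c1N/N=N/Cc1ccccc1` gives > 50000 nM (a limit)

Compound 3 gives > 50000 nM as a limit of the assay and not a number. Its place is shared with compounds 1 and 2 (the limit of > 50000 nM in this assay, at which 3 of the 3 values shown sit), and no order among the three can be read.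

Compound 4 `NC(=O)c1nc[nH]c1N/N=N/Cc1ccoc1` has not yet been tested. Among the measured compounds shown here, it differs from compound 3 in one place, with furan-3-yl in place of phenyl on a saturated chain carbon bound to a double-bonded nitrogen as the single change. For the measured compounds named here, no two measured compounds differ in just one place, so no earlier step shows what such a swap does.

Going by the values given here, compound 3, with its limit of > 50000 nM in this assay, is the only close guide, and another limit is the most likely result for compound 4. The expected step (a number no higher from compound 3 to compound 4 (the limit leaves the size open)) is none beyond the scatter, in either direction. For compound 4 the estimate is 50000 nM (expected range 25000 nM to 100000 nM).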

Compound 4, concentration for 50% growth inhibition: > 50000 nM
Compound 4 was reported as a limit; the forecaster's own chance of this, stated with the estimate: 85%; the middle value lies on the limit itself.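

In this assay compound 4 gives > 50000 nM, which is a limit and not a number. Compound 3 also stands at a limit, so no step can be read for the swap of phenyl for furan-3-yl between compound 3 and compound 4. Every compound shown sits at the same place: the limit of > 50000 nM in this assay, at which 4 of the 4 values shown sit.

The compounds shown leave open how strongly any of them inhibits growth, and whether this swap changes that at all.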